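Benzylamine variation in the bis(trifluoromethyl)sulfonamide series

The source may report more compounds than this note shows. Statements on the series, on what has been measured and on what is new or still open speak of the compounds shown alone.

Measured so far:
compound 1 `O=S(=O)(NCCCNCc1ccc(C(F)(F)F)cc1)c1cc(C(F)(F)F)cc(C(F)(F)F)c1` — 3200 nM
compound 2 `O=S(=O)(NCCCNCc1ccc(-c2ccccc2)cc1)c1cc(C(F)(F)F)cc(C(F)(F)F)c1` — 2500 nM

In a functional assay on PANC-1 cells (Homo sapiens) for inhibition, read by MTT assay, with a stated time of 72 h (a higher number here means a weaker inhibitor of growth, a lower number a stronger inhibitor of growth), compound 1 gives 3200 nM, the highest of the two numbers, while compound 2 gives 2500 nM; the step of a 1.3-fold lower number from compound 1 to compound 2 (0.11 log units; within the scatter) lies within the scatter. Compound 3 `O=S(=O)(NCCCNCc1cccc(Cl)c1)c1cc(C(F)(F)F)cc(C(F)(F)F)c1` differs from compound 1 by 3-chlorophenyl in place of 4-(trifluoromethyl)phenyl on a saturated chain carbon bound to an amine nitrogen. Among the measured compounds shown here, no measured step covers a chlorophenyl; the one change made at this position, from compound 1 to compound 2, stayed within the scatter. For compound 3 no step beyond the scatter is therefore expected, estimated as a 1.1-fold lower number from compound 1 to compound 3 (0.03 log units; within the scatter). Compound 3 is expected at 3000 nM, range 1500 nM to 7000 nM.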

Compound 3, concentration for 50% growth inhibition: 12000 nM
For compound 3 the middle estimate is 4.0-fold (0.60 log units) below the measured one; measured number outside the range, above it.
By their numbers in this assay, from the lowest: compounds 2 and 1 (each within the scatter of the next); then compound 3.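

Among the compounds shown here, the benzyl group is not indifferent in this assay: 3-chlorophenyl in place of 4-(trifluoromethyl)phenyl gives a 3.8-fold higher number from compound 1 to compound 3 (0.57 log units; beyond the scatter), the first step at this position beyond the scatter, and the direction is towards weaker growth inhibition. No supporting data bear on why this step occurs.

The compounds shown do not separate the change of substituent from the change of its ring position, as both differ in compound 3. Also open, going by these compounds, is how a nitrile or a methoxy group on this ring, or a longer chain, would read.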